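Removing a methoxy group from a pyrazolyl chalcone scaffold

The source may hold more compounds than are shown below. What is called first, only, known or untested is meant among the compounds shown, and "the series" means these compounds.

Measured compounds:
compound 1 `COc1ccc(-c2cc(/C=C/C(=O)c3ccc(N)cc3)[nH]n2)cc1` gives 84% in a functional assay on NCI-H522 cells (Homo sapiens) for cytotoxicity, read by sulforhodamine B assay, with a stated time of 48 h, tested at 0.01 uM; on this read-out lower numbers stand for a stronger effect and higher numbers for a weaker effect at the one concentration tested
compound 2 `COc1cc(-c2cc(/C=C/C(=O)c3ccc(N)cc3)[nH]n2)cc(OC)c1OC` gives 92% in this assay

Compound 2 has the highest of the two numbers recorded in this assay, but its nearest neighbour, compound 1, sits only a little lower, a gap that lies within the usual scatter of the read-out, so the two values cannot be ordered against each other. Compound 3 `COc1ccc(-c2cc(/C=C/C(=O)c3ccc(N)cc3)[nH]n2)cc1OC` has not yet been measured in this assay. It differs from compound 2 in one place: hydrogen in place of methoxy on an aromatic carbon. With both measured compounds giving values that agree within the scatter, there is no basis for expecting the change to move the number beyond the scatter in either direction. The step from compound 2 to compound 3 is therefore expected to be a number 4 percentage points lower from compound 2 to compound 3 (within the scatter), within the scatter. Compound 3 is estimated to give 88% in this assay, with a range from 76% to 100%.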

Compound 3, a percentage reported as activity, at one concentration (the size of the read-out at that concentration, not a potency): 92%
Compound 3: middle estimate off by 4 percentage points, on the low side; the range from low to high includes it.
By their numbers in this assay, from the lowest: compounds 1, 2 and 3 (each within the scatter of the next).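

In this assay, hydrogen in place of methoxy on an aromatic carbon gives no change at the digits printed from compound 2 to compound 3 (within the scatter), and methoxy in place of hydrogen on an aromatic carbon gives a number 8 percentage points higher from compound 1 to compound 3 (within the scatter). Each of these single changes therefore stays within the scatter at the one concentration tested, something compound 1 and compound 2 could not show, as they differ in more than one place. No measured evidence bears on these results.

From the compounds shown here alone, the three compounds carry only methoxy or hydrogen on this ring, so it remains open what a hydroxy group, a fluorine atom or an amine at this place would do to the read-out. Also open, going by these compounds, is whether these changes would stay within the scatter at a higher concentration.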